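Swapping the Ring on the Amine of Compound 2

This account rests on a few compounds, and the source may have more. Where it says the series, first, only, none or still open, it means among the compounds named here.

Of the compounds shown here, two have been measured in an ADME assay on cells (Hepatocyte, Homo sapiens) for metabolic stability, with a stated time of 90 min; on this read-out higher numbers stand for fast clearance and lower numbers for slow clearance. Compound 1 `CCC(CC)CNc1c(C(N)=O)cnc2ccc(C#N)cc12` gives 12 uL/min. Compound 2 `NC(=O)c1cnc2ccc(-c3cccnc3)cc2c1NC1CCCC1` gives 23 uL/min, a number that sits within the usual scatter of compound 1, so the two cannot be told apart. Compound 3 `NC(=O)c1cnc2ccc(-c3cccnc3)cc2c1NCC1CCCCC1` has not been measured in this assay. The change from compound 2 is cyclohexylmethyl in place of cyclopentyl on a nitrogen on an aromatic ring. For the measured compounds named here, with no measured pair showing a comparable change, the step is expected to be modest and toward faster clearance: a 1.7-fold higher number from compound 2 to compound 3 (0.24 log units; within the scatter). Compound 3 is therefore estimated at 40 uL/min, with a range from 15 uL/min to 100 uL/min.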

Compound 3, intrinsic clearance in a liver preparation (reported as CLH), per the amount of preparation that the assay uses: 40 uL/min
Compound 3: the middle estimate sits on the measured number at the digits printed; low and high end bracket the measured number.
By their numbers in this assay, from the lowest: compounds 1, 2 and 3 (each within the scatter of the next, the first and the last beyond it).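

Putting cyclohexylmethyl in place of cyclopentyl on this nitrogen gives a 1.7-fold higher number from compound 2 to compound 3 (0.24 log units; within the scatter) in this assay. So at this position, a six-membered ring on a methyl link and a five-membered ring attached directly cannot be told apart by clearance, which the earlier compounds, differing in more than one place, could not show. Nothing measured here explains the result. Still open, as far as these compounds go, is what happens when this carbon-only ring gives way to a group containing oxygen or nitrogen, such as tetrahydropyranylmethyl or a piperidine ring.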